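The source may hold more compounds than are shown below. What is called first, only, known or untested is meant among the compounds shown, and "the series" means these compounds.

Measured so far in an ADME assay on SK-OV-3 cells (Homo sapiens) for cytotoxicity, read by sulforhodamine B assay, with a stated time of 48 h, tested at 10 uM; a higher number here means more inhibition at the concentration tested (going by the name of the read-out), a lower number less inhibition:
- compound 1, `COc1nc2ccc(Br)cc2cc1C(c1ccccc1)n1cc(-c2ccc(Br)cc2)nn1` — 13.4%
- compound 2, `CCCCCCc1cn(C(c2ccccc2)c2cc3cc(Br)ccc3nc2OC)nn1` — 7.17%
- compound 3, `COc1nc2ccc(Br)cc2cc1C(c1ccccc1)n1cc(CCO)nn1` — 8.46%

All three share one core and differ only in the group on the five-membered ring with three nitrogens. On the raw numbers compound 3 sits between the other two, but every step is within the scatter: a number 4.9 percentage points lower from compound 1 to compound 3 (within the scatter), a number 1.3 percentage points higher from compound 2 to compound 3 (within the scatter), and a number 6.2 percentage points lower from compound 1 to compound 2 (within the scatter). Nothing in this assay separates these three compounds.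

Compound 4, `COc1nc2ccc(Br)cc2cc1C(c1ccccc1)n1cc(-c2cccc(F)c2)nn1`, is the next member. Relative to compound 3 the change is 3-fluorophenyl in place of 2-hydroxyethyl on an aromatic carbon. Among the compounds with values here, the step that bears on it most directly is the reverse of the one from compound 1 to compound 3, where an aryl group gave way to 2-hydroxyethyl and the number moved by a number 4.9 percentage points lower from compound 1 to compound 3 (within the scatter). Putting an aryl group back is therefore expected to move the number at most by a similar small amount, if at all, toward the value of compound 1. For compound 4 the expected step is a number 2.5 percentage points higher from compound 3 to compound 4 (within the scatter), and the estimate is 11% with a range of 2% to 21%.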

Compound 4, a percentage reported as inhibition, at one concentration (the size of the read-out at that concentration, not a potency): 12.7%
Beside the measured number, compound 4's estimate is 1.7 percentage points below it; the range from low to high includes it.
By their numbers in this assay, from the lowest: compounds 2, 3, 4 and 1 (each within the scatter of the next).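

Working notes on the aromatic carbon of the five-membered ring with 3 nitrogen, in this assay: 3-fluorophenyl in place of 2-hydroxyethyl gives a step within the scatter (a number 4.2 percentage points higher from compound 3 to compound 4 (within the scatter)), and the same holds against hexyl (a number 5.5 percentage points higher from compound 2 to compound 4 (within the scatter)). A second aryl group, compared with 4-bromophenyl, also leaves the read-out within the scatter (a number 0.7 percentage points lower from compound 1 to compound 4 (within the scatter)), so neither the swap from 4-bromophenyl to 3-fluorophenyl nor the swap from either chain to 3-fluorophenyl separates these compounds. No supporting data bear on why these steps stay this small.

Going by these compounds, whether any group at this carbon gives a step beyond the scatter remains open, for example a carboxylic acid or an aminoethyl chain. The compounds shown also leave open whether a change elsewhere on the shared core, such as replacing the methoxy group, would do so.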